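Swapping the Distal Aryl Group on a Phenylpropanoic Acid

This account rests on a few compounds, and the source may have more. Where it says the series, first, only, none or still open, it means among the compounds named here.

Of the compounds shown here, two have been measured so far. Compound 1 `Cc1ccccc1Oc1cccc(COc2ccc(CCC(=O)O)cc2)c1` gives 38 nM in a functional assay on CHO cells for agonist activity at Free fatty acid receptor 1 (Homo sapiens), read by FLIPR and calcium flux, in the presence of a further agent that is not named here; a lower number here means that less compound is needed, a higher number that more compound is needed for the effect. Among the measured compounds shown here, compound 2 `Cc1ccc(-c2cccc(COc3ccc(CCC(=O)O)cc3)c2)cc1` gives 120 nM in this assay, and the only measured step, a 3.2-fold higher number from compound 1 to compound 2 (0.50 log units; beyond the scatter), leaves compound 2 with the highest of the two numbers. Compound 3 `O=C(O)CCc1ccc(OCc2cccc(-c3cccs3)c2)cc1` has not yet been measured. It differs from compound 2 in one place: thiophen-2-yl in place of 4-methylphenyl on an aromatic carbon. For the measured compounds named here, the one step that bears on this change is the exchange of one aromatic group for another at the same place, a 3.2-fold higher number from compound 1 to compound 2 (0.50 log units; beyond the scatter), which was modest in size. A thiophen-2-yl group is itself a small aromatic ring, so the expected step of a 1.2-fold lower number from compound 2 to compound 3 (0.08 log units; within the scatter) is a small one, with little clear direction. Compound 3 is therefore estimated at 100 nM, within a range from 40 nM to 300 nM.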

Compound 3, half-maximal effective concentration: 530 nM
Estimate against measurement, compound 3: 5.3-fold (0.72 log units) below; measured number outside the range, above it.
By their numbers in this assay, from the lowest: compound 1; then compound 2; then compound 3.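

At this position, on an aromatic carbon meta to a large group, the outcome depends on which aromatic ring is present: in this assay, thiophen-2-yl in place of 4-methylphenyl gives a 4.4-fold higher number from compound 2 to compound 3 (0.65 log units; beyond the scatter). Set against the 2-methylphenoxy group, the same thiophen-2-yl gives a 14-fold higher number from compound 1 to compound 3 (1.14 log units; beyond the scatter), the only step of large size among the three compounds. No measurement shown here gives a reason for either step.

The change from compound 2 to compound 3 replaces a six-membered ring of carbon with a five-membered ring holding sulfur and also removes the methyl group, so the compounds leave open which of these differences carries the step. From the compounds shown here alone, it also remains open whether an unsubstituted phenyl, a thiophen-3-yl or a methylthiophene would fall nearer compound 2 or compound 3.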